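Dimethylamino for acetyl on the outer aryl of compound 1

The source may report more compounds than this note shows. Statements on the series, on what has been measured and on what is new or still open speak of the compounds shown alone.

compound 1 `COc1cc(C)cc(-c2c(-c3ccnc(-c4ccc(C(C)=O)cc4)c3)cnn2CC#N)c1` — 2130 nM
compound 2 `Cc1cc(O)cc(-c2nn(CC#N)cc2-c2ccnc(-c3ccc(Oc4ccccc4)cc3)c2)c1` — 8280 nM
compound 3 `Cc1cc(O)cc(-c2nn(CC#N)cc2-c2ccnc(-c3ccc(N(C)C)cc3)c2)c1` — 9940 nM

All three were read in a functional assay on MDA-MB-468 cells (Homo sapiens) for inhibition, read by sulforhodamine B assay, with a stated time of 48 h; on this read-out lower numbers stand for higher toxicity in this test and higher numbers for lower toxicity in this test. Compound 1 gives the lowest number of the three; compound 2 and compound 3 both stand higher, each beyond the scatter from compound 1, while they lie within the scatter of each other. Compound 4 `COc1cc(C)cc(-c2c(-c3ccnc(-c4ccc(N(C)C)cc4)c3)cnn2CC#N)c1` is not yet measured. It differs from compound 1 in one place: dimethylamino in place of acetyl on an aromatic carbon. Within the data shown here, no measured pair carries exactly this exchange. Among the measured compounds shown here, the single measured step in this assay, a 1.2-fold higher number from compound 2 to compound 3 (0.08 log units; within the scatter), brings dimethylamino onto an aromatic carbon in place of another group and leaves the number essentially unchanged. Compound 1 and compound 2 differ in more than one place, so their gap cannot be charged to the acetyl alone. On this basis the step of a 1.4-fold higher number from compound 1 to compound 4 (0.15 log units; within the scatter) is expected to be small, with no firm direction beyond the scatter, leaning if anything toward a slightly higher number. Compound 4 is therefore estimated at 3000 nM, with a range of 1200 nM to 7500 nM.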

Compound 4, concentration lethal to 50% of the cells: 1040 nM
For compound 4 the middle estimate is 2.9-fold (0.46 log units) above the measured one; the whole stated range lies above it.
By their numbers in this assay, from the lowest: compound 4; then compound 1; then compounds 2 and 3 (each within the scatter of the next).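

In this assay, the change from 4-acetylphenyl to 4-(dimethylamino)phenyl gives a 2.0-fold lower number from compound 1 to compound 4 (0.31 log units; beyond the scatter), so this position, para to a large group, responds modestly to the exchange even though the two groups match in heavy atoms and hydrogen-bond acceptors. Among these compounds, the only earlier step bringing in dimethylamino, a 1.2-fold higher number from compound 2 to compound 3 (0.08 log units; within the scatter), replaced phenoxy on a different parent, so the entering group alone does not set the outcome across these compounds. Nothing available explains the step from acetyl to dimethylamino.

Open, going by these compounds, is whether other amines at this position, such as a primary amine or morpholine, follow dimethylamino or stay nearer acetyl. A carboxylic acid in the same place would show whether the number moves the opposite way on the core of compound 1.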